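This account rests on a few compounds, and the source may have more. Where it says the series, first, only, none or still open, it means among the compounds named here.

Measured so far in an ADME assay on Huh-5-2 cells (Homo sapiens) for cytotoxicity, read by WST assay, with a stated time of 3 days; a higher number here means that more compound is tolerated, a lower number that less compound is tolerated:
Compound 1, `O=c1c(O)c(-c2ccccc2)oc2cc(OCc3cccc(Br)c3)cc(O)c12`: in this assay compound 1 reaches only a limit, > 100000 nM.
Compound 2, `O=c1c(O)c(-c2ccccc2)oc2cc(OCc3cccc([N+](=O)[O-])c3)cc(O)c12`: compound 2 gives 76000 nM.

Compound 2 thus holds the only number shown; the other result is a limit (the limit of > 100000 nM in this assay, at which 1 of the 2 values shown sits). Among the compounds with values here, the one measured step, an at least 1.3-fold lower number from compound 1 to compound 2 (0.11 log units; that floor lies within the scatter), exchanged a group at the same place and stayed within the scatter. Compound 3, `Cc1cccc(COc2cc(O)c3c(=O)c(O)c(-c4ccccc4)oc3c2)c1`, differs from compound 2 by methyl in place of nitro on an aromatic carbon. Within the data shown here, with only that small step to go on, no change beyond the scatter is expected for compound 3, whose value in this assay is estimated at 90000 nM, between 40000 nM and 200000 nM. The expected step is a 1.2-fold higher number from compound 2 to compound 3 (0.07 log units; within the scatter).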

Compound 3, half-maximal cytotoxic concentration: 35000 nM
Compound 3: the middle estimate sits 2.6-fold (0.41 log units) above what was measured, outside the stated range (below it).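

In this assay, this position on the benzyl ring can move the tolerated concentration beyond the scatter: methyl in place of nitro gives a 2.2-fold lower number from compound 2 to compound 3 (0.34 log units; beyond the scatter), whereas the floor of the earlier step stayed within it. Methyl in place of bromo gives an at least 2.8-fold lower number from compound 1 to compound 3 (0.45 log units; beyond the scatter), so the 3-methylbenzyl compound stands apart from both others. That second step is only a floor, and compound 1 reaches only a limit: the limit of > 100000 nM in this assay, at which 1 of the 3 values shown sits.

The compounds shown leave open how far bromo and nitro truly lie apart. They also leave open whether the lower number belongs to methyl alone or would also appear with an ethyl, a methoxy or an amine at this place.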